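Hydroxy to methoxy on the pyrrolidine of compound 3

This account rests on a few compounds, and the source may have more. Where it says the series, first, only, none or still open, it means among the compounds named here.

Measured so far, in a functional assay on HEK293 cells for agonist activity at Vasopressin V2 receptor (Homo sapiens), read by a luciferase reporter and cAMP accumulation; a lower number here means that less compound is needed, a higher number that more compound is needed for the effect:
compound 1 `Cc1cc(C(=O)N2CCCCc3ccccc32)ccc1CNC(=O)NCC(=O)OC(C)C` gives 140 nM
compound 2 `Cc1cc(C(=O)N2CCCCc3ccccc32)ccc1CNC(=O)N1CCC[C@H]1C(=S)N(C)C` gives 3.2 nM
compound 3 `Cc1cc(C(=O)N2CCCCc3ccccc32)ccc1CNC(=O)N1C[C@H](O)C[C@H]1C(=O)N(C)C` gives 2.3 nM

Compound 3 has the lowest number of the three. Its nearest neighbour is compound 2, and the two lie within the scatter of each other: a 1.4-fold lower number from compound 2 to compound 3 (0.14 log units; within the scatter). The gap to compound 1 is large: a 61-fold lower number from compound 1 to compound 3 (1.78 log units; beyond the scatter); so is the related step of a 44-fold lower number from compound 1 to compound 2 (1.64 log units; beyond the scatter).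

Compound 4 `CO[C@@H]1C[C@@H](C(=O)N(C)C)N(C(=O)NCc2ccc(C(=O)N3CCCCc4ccccc43)cc2C)C1` is next. Against compound 3 the change is methyl in place of hydrogen on an oxygen on a saturated carbon, that is, hydroxy to methoxy on the pyrrolidine.

Among the compounds with values here, no measured step bears directly on this change. Within the data shown here, the large steps from compound 1 rest on replacing the whole open-chain ester group by a pyrrolidine bearing a dimethylcarbamoyl or its thio analogue; the only step that touches the hydroxy-bearing position is a 1.4-fold lower number from compound 2 to compound 3 (0.14 log units; within the scatter), where the ring without a hydroxy and the ring with one read within the scatter of each other. The methyl cap is therefore expected to make little difference, and for compound 4 a step of a 1.3-fold higher number from compound 3 to compound 4 (0.12 log units; within the scatter) is estimated, within the scatter. For compound 4 the number in this assay is estimated at 3 nM, in a range from 1 nM to 10 nM.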

Compound 4, half-maximal effective concentration: 4.7 nM
Beside the measured number, compound 4's estimate is 1.6-fold (0.19 log units) below it; measured number inside the range.
By their numbers in this assay, from the lowest: compounds 3, 2 and 4 (each within the scatter of the next, the first and the last beyond it); then compound 1.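

In this assay the methyl cap on the oxygen gives a 2.0-fold higher number from compound 3 to compound 4 (0.31 log units; beyond the scatter), a modest step and the first one at this position that is printed as beyond the scatter, so replacing the hydroxy hydrogen does register here, though only just. The methoxy compound still keeps most of the gain over the open-chain ester, with a 30-fold lower number from compound 1 to compound 4 (1.47 log units; beyond the scatter), and a 1.5-fold higher number from compound 2 to compound 4 (0.17 log units; within the scatter) stays within the scatter, so a free hydroxy is not needed to hold a number in the range of the other pyrrolidine ureas shown. No evidence on the origin of the step from hydroxy to methoxy is available.

With a single capped example, the compounds shown do not tell whether the trend continues with a longer ether such as ethoxy or benzyloxy, or how an amine or a fluorine on the same saturated carbon would read. They also leave open whether the opposite configuration at that carbon changes the picture, and whether the same methyl cap would give a comparable step on the sulfur-containing analogue.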